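From hydroxy to methoxy on compound 2

A few compounds are considered here, and "the series" means these few. Any claim that something is new, unique, unknown or untested is made for them only; others in the source may bear on it.

Compound 1 `Oc1ccc(/C=C/c2cccc(O)c2)cc1`: 23 ug/mL
Compound 2 `Nc1cccc(/C=C/c2ccc(O)cc2)c1`: 6 ug/mL

In a functional assay on MCF7 cells (Homo sapiens) for inhibition, read by MTT assay, with a stated time of 2 days (a lower number here means a stronger inhibitor, a higher number a weaker inhibitor), compound 2 holds the lower of the two numbers, at 6 ug/mL. Compound 3 `COc1ccc(/C=C/c2cccc(N)c2)cc1` differs from it by methyl in place of hydrogen on an oxygen on an aromatic ring, or hydroxy to methoxy. Within the data shown here, the one measured step, a 3.8-fold lower number from compound 1 to compound 2 (0.58 log units; beyond the scatter), is a different change, amino in place of hydroxy, so it shows only how far one small change can move the number. Among the measured compounds shown here, no measured pair tests the new change, so no step beyond the scatter is expected, and the direction stays open. The expected step is a 1.2-fold lower number from compound 2 to compound 3 (0.08 log units; within the scatter). For compound 3 the estimated value is 5 ug/mL, with an expected range of 1.5 ug/mL to 20 ug/mL.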

Compound 3, half-maximal inhibitory concentration: 23 ug/mL
For compound 3 the middle estimate is 4.6-fold (0.66 log units) below the measured one; measured number outside the range, above it.
By their numbers in this assay, from the lowest: compound 2; then compounds 1 and 3 (each within the scatter of the next).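

Hydroxy to methoxy on the shared core gives a 3.8-fold higher number from compound 2 to compound 3 (0.58 log units; beyond the scatter) in this assay. The hydrogen on this oxygen on an aromatic ring is therefore not a free place to build on: a single added methyl gives weaker inhibition, a step of the same size as the one seen earlier for a different change. Nothing in the data explains this loss.

From the compounds shown here alone, whether a longer chain on the same oxygen, such as ethoxy, would raise the number further stays open. So does whether an amine or a fluorine in place of that oxygen would keep the number of compound 2.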